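The source may hold more compounds than are shown below. What is called first, only, known or untested is meant among the compounds shown, and "the series" means these compounds.

Within the data shown here, compound 3 `C[C@@H](O)CNc1cc(Oc2ccc(NC(=O)Nc3cccc(C(F)(F)F)c3)cc2)ncn1` stands lowest of the three compounds measured so far in an assay on isolated protein for inhibition of serine/threonine-protein kinase TNNI3K (Homo sapiens); a higher number here means a weaker inhibitor, a lower number a stronger inhibitor. Compound 1 `O=C(Nc1ccc(Oc2ccncn2)cc1)Nc1cccc(C(F)(F)F)c1` gives 160 nM in this assay, and compound 2 `O=C(Nc1ccc(Oc2cc(O)ncn2)cc1)Nc1cccc(C(F)(F)F)c1` gives 3200 nM. The step of a 20-fold higher number from compound 1 to compound 2 (1.30 log units; beyond the scatter) puts hydroxy in place of hydrogen on an aromatic carbon, whereas the step of a 2.5-fold lower number from compound 1 to compound 3 (0.40 log units; beyond the scatter) puts (2-hydroxypropyl)amino in the same place; between the two substituted compounds lies the step of a 51-fold lower number from compound 2 to compound 3 (1.71 log units; beyond the scatter). In this assay compound 3 gives 63 nM.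

Compound 4 `C[C@H](O)CNc1cc(Oc2ccc(NC(=O)Nc3cccc(C(F)(F)F)c3)cc2)ncn1` differs from compound 3 in one respect only: the two compounds have the same atoms and bonds and differ only in configuration as drawn: 1 of 1 stereo elements differ; a stereocentre at a saturated chain carbon is drawn R in compound 3 and S in compound 4. Among the measured compounds shown here, none of the measured steps bears directly on such a change, since each of them exchanges one group for another and none compares the two drawn configurations of the same group. The steps starting from compound 1 show that what sits at this place matters a great deal, but they give no guide to the direction or the size of a change in configuration alone. A step of a 1.6-fold higher number from compound 3 to compound 4 (0.20 log units; within the scatter) is therefore expected to be small, most likely within the usual scatter, with a wide allowance since neither direction can be ruled out. Compound 4 is expected to give 100 nM in this assay, within a range from 30 nM to 400 nM.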

Compound 4, half-maximal inhibitory concentration: 32 nM
Estimate against measurement, compound 4: 3.1-fold (0.49 log units) above, and the stated range covers the measured number.
By their numbers in this assay, from the lowest: compounds 4 and 3 (each within the scatter of the next); then compound 1; then compound 2.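

In this assay, moving from the R to the S drawing of the stereocentre on the saturated chain carbon gives a 2.0-fold lower number from compound 3 to compound 4 (0.29 log units; within the scatter) and stays within the scatter, so this measurement cannot tell the two configurations apart. Either configuration of the (2-hydroxypropyl)amino group outperforms both the hydrogen and the hydroxy at this place: a 2.5-fold lower number from compound 1 to compound 3 (0.40 log units; beyond the scatter) and a 5.0-fold lower number from compound 1 to compound 4 (0.70 log units; beyond the scatter) are modest steps of similar kind, while a 51-fold lower number from compound 2 to compound 3 (1.71 log units; beyond the scatter) and a 100-fold lower number from compound 2 to compound 4 (2.00 log units; beyond the scatter) are both large. The pair gives a clean test of the stereocentre alone, because nothing else separates the two compounds: the fact that compounds 3 and 4 differ only in the configuration as drawn.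

The compounds shown leave open which part of the (2-hydroxypropyl)amino group supports the lower numbers, the amine nitrogen or the hydroxy on the chain. A plain propylamino group, a methoxy in place of that hydroxy, or a longer chain carrying the hydroxy would help separate these parts and show whether the configuration matters more in other chains.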